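The source may hold more compounds than are shown below. What is called first, only, known or untested is meant among the compounds shown, and "the series" means these compounds.

Working notes on the series

Compound 1 `CC(=O)Nc1ccc(O)c(C(=O)/C=C/c2ccc(F)cc2)c1` and compound 2 `CC(=O)Nc1ccc(O)c(C(=O)/C=C/c2ccc(C(F)(F)F)cc2)c1` share one core; compound 3 `Nc1ccc2oc(-c3cccc(F)c3)c(O)c(=O)c2c1` and compound 4 `Nc1ccc2oc(-c3cccc(C(F)(F)F)c3)c(O)c(=O)c2c1` share another. The difference between the two cores is not broken down here. Within the first pair, compound 2 differs from compound 1 by trifluoromethyl in place of fluoro on an aromatic carbon. Within the second pair, compound 4 differs from compound 3 by trifluoromethyl in place of fluoro on an aromatic carbon. The two changes are of the same kind but are not the same: in compound 2 the trifluoromethyl sits para to a large group, in compound 4 it sits meta to a large group.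

In an ADME assay on MT4 cells (Homo sapiens) for cytotoxicity, read by MTT assay, with a stated time of 4 days (a higher number here means that more compound is tolerated, a lower number that less compound is tolerated), compound 1 gives 41100 nM. In this assay compound 2 gives 21100 nM, and the step of a 1.9-fold lower number from compound 1 to compound 2 (0.29 log units; within the scatter). In this assay compound 3 gives 35300 nM, which lies within the scatter of both compound 1 and compound 2.

Within the data shown here, for compound 4 the expectation rests on the one measured instance of this kind of change, the step of a 1.9-fold lower number from compound 1 to compound 2 (0.29 log units; within the scatter), carried over to the core of compound 3. The step from compound 3 to compound 4 is therefore estimated at a 1.6-fold lower number from compound 3 to compound 4 (0.21 log units; within the scatter), a move that would again lie within the scatter. Compound 4 is expected to give 22000 nM in this assay, with a likely range from 10000 nM to 50000 nM.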

Compound 4, half-maximal cytotoxic concentration: 8100 nM
The estimate for compound 4 lay 2.7-fold (0.43 log units) above the measured number, outside the stated range (below it).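

Trifluoromethyl in place of fluoro on an aromatic carbon gives a 4.4-fold lower number from compound 3 to compound 4 (0.64 log units; beyond the scatter) in this assay, a step that stands beyond the scatter, whereas on the other core the same kind of change gives a 1.9-fold lower number from compound 1 to compound 2 (0.29 log units; within the scatter), a step that stands within it. Both steps point to a lower number, which supports carrying the direction of this change from one core to the other, and the larger step on the core of compound 3 cannot be told apart from the smaller one: the same change on two cores in this assay, a 1.9-fold lower number (0.29 log units; within the scatter) from compound 1 to compound 2 and a 4.4-fold lower number (0.64 log units; beyond the scatter) from compound 3 to compound 4, 2.2-fold (0.35 log units) apart, within the scatter of two such steps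

Among these compounds, this does not show that the size of the step carries over, or that the core alters it, as the comparison rests on only two pairs, and the trifluoromethyl does not sit in the same place in compound 2 and compound 4.

Open, as far as these compounds go, is whether the two steps would stay alike with the trifluoromethyl in one and the same place on both cores, which would separate a difference of place from a difference of core. Also open, from the compounds shown here alone, is how other groups in that place, such as a nitrile, a methoxy group or a carboxylic acid, would read in this assay on either core.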